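Methoxy for methyl on an aryl hydrazone: cytotoxicity outlook

The compounds below may be only part of what the source reports. "The series", "measured", "known", "first", "only" and "open" are said of these compounds alone.

Compound 1 `Cc1ccc(N2CCn3c2n[nH]c(=O)c3=O)cc1` and compound 2 `Cc1ccc(N2CCN/C2=N\N)cc1` carry the same aryl group on different cores. In an ADME assay on Vero cells (Chlorocebus sabaeus) for cytotoxicity, with a stated time of 72 h, tested at 10 ug/mL (on this read-out lower numbers stand for a weaker effect and higher numbers for a stronger effect at the one concentration tested), compound 1 gives 0%. In this assay compound 2 gives 0%, level with compound 1 at the digits shown, a difference within the scatter. Compound 3 `COc1ccc(N2CCN/C2=N\N)cc1` differs from compound 2 in one place: methoxy in place of methyl on an aromatic carbon. Among the measured compounds shown here, no step between measured compounds is available for this change, so its size in this assay cannot be read from the data. Compound 1 at 0% and compound 2 at 0% both sit at the bottom of the scale, so the expectation is a step of no size beyond the scatter, in neither direction. Compound 3 is therefore estimated to give 0% in this assay, within a range from -5% to 10%. The step that this estimate means, no change at the digits printed from compound 2 to compound 3 (within the scatter), is expected to stay within the scatter.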

Compound 3, a percentage reported as inhibition, at one concentration (the size of the read-out at that concentration, not a potency): 0%
The estimate for compound 3 equals the measured number at the digits printed, and the stated range covers the measured number.
By their numbers in this assay, from the lowest: compounds 1, 2 and 3 (each within the scatter of the next).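

In this assay, among the compounds shown here, the change of methyl to methoxy on an aromatic carbon, para to a group of 7 heavy atoms, gives no change at the digits printed from compound 2 to compound 3 (within the scatter) on the hydrazone core, the first reading for any change at this position. The earlier compounds shown here differed in their cores, whereas this pair shows that this one exchange, which brings in a hydrogen-bond acceptor, does not move the read-out beyond the scatter at the one concentration tested. Nothing at hand bears on why the step has this size.

As far as these compounds go, whether an amine, a carboxylic acid or a longer chain such as ethoxy on this same carbon would give a read-out apart from that of compound 3 stays open. So does whether methoxy in place of methyl would behave in the same way on the core of compound 1.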